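Working notes: from compound 3 to compound 4

The source may hold more compounds than are shown below. What is called first, only, known or untested is meant among the compounds shown, and "the series" means these compounds.

Measured so far:
compound 1 `CCc1ccccc1N(CC(=O)OCc1ccc(OC)cc1)S(=O)(=O)c1ccc(C)cc1` — 63 nM; 63.1 nM (2 entries)
compound 2 `COc1ccc(Cc2nnc(CN(c3cccc(C(F)(F)F)c3C)S(=O)(=O)c3ccc(C)cc3)o2)cc1` — 63.1 nM
compound 3 `Cc1ccc(S(=O)(=O)N(Cc2nnc(Cc3ccc(N(C)C)cc3)o2)c2cccc(Cl)c2C)cc1` — 12.6 nM

In an assay on CHO cells for displacement of a labelled ligand from prostaglandin E2 receptor EP1 subtype (Homo sapiens) (on this read-out lower numbers stand for stronger inhibition and higher numbers for weaker inhibition), compound 3 gives 12.6 nM, the lower of the two single numbers in the set. Compound 2 gives 63.1 nM, a gap to compound 3 that lies beyond the usual scatter. Compound 1 carries repeated entries rather than a single number, as seen in the several entries of compound 1 in this assay, 63 nM; 63.1 nM (2 entries), and is not compared further here.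

Compound 4 `Cc1ccc(S(=O)(=O)N(Cc2nnc(Cc3c(Cl)cccc3Cl)o2)c2cccc(Cl)c2C)cc1` differs from compound 3 in one place: 2,6-dichlorophenyl in place of 4-(dimethylamino)phenyl on a saturated chain carbon bound to an aromatic carbon. Among the measured compounds shown here, no pair of measured compounds differs at this position, so no measured step gives the direction or size of the change in this assay. The expectation is a step towards a weaker result, of moderate size, with the chance that it stays within the scatter left open. Compound 4 is expected at 25 nM, with a range from 6 nM to 100 nM. The estimated step of a 2.0-fold higher number from compound 3 to compound 4 (0.30 log units; within the scatter) is therefore a modest rise in the number.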

Compound 4, half-maximal inhibitory concentration: 63.1 nM
For compound 4 the middle estimate is 2.5-fold (0.40 log units) below the measured one, and the stated range covers the measured number.
By their numbers in this assay, from the lowest: compound 3; then compounds 2 and 4 (each within the scatter of the next).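

In this assay, among the compounds shown here, the saturated chain carbon bound to an aromatic carbon is the first position where a single change can be read: 2,6-dichlorophenyl in place of 4-(dimethylamino)phenyl gives a 5.0-fold higher number from compound 3 to compound 4 (0.70 log units; beyond the scatter) in this series. The earlier compounds shown here offered no pair differing in one place, so the direction and size of a change here were unknown until now. The results shown give no reason for this step.

Two things change together in this step: the 4-(dimethylamino)phenyl group leaves and the 2,6-dichlorophenyl group enters, so their separate contributions remain unresolved. An unsubstituted phenyl at this place would help separate them, while a carboxylic acid on the same ring would test a different kind of group there.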